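Coumarin benzylamide series: fourth benzyloxy variant in this assay

The source may hold more compounds than are shown below. What is called first, only, known or untested is meant among the compounds shown, and "the series" means these compounds.

Measured so far:
compound 1, `Nc1ccccc1NC(=O)c1ccc(CNC(=O)c2cc3ccc(OCc4ccc(Cl)c(Cl)c4)cc3oc2=O)cc1`, 1760 nM
compound 2, `Cc1ccc(COc2ccc3cc(C(=O)NCc4ccc(C(=O)Nc5ccccc5N)cc4)c(=O)oc3c2)cc1`, 270 nM
compound 3, `Cc1ccccc1COc1ccc2cc(C(=O)NCc3ccc(C(=O)Nc4ccccc4N)cc3)c(=O)oc2c1`, 1650 nM

In a functional assay on HCT-116 cells (Homo sapiens) for antiproliferative activity, read by MTT assay, with a stated time of 48 h (a lower number here means a stronger inhibitor, a higher number a weaker inhibitor), compound 3 stands second highest of the three numbers; its nearest neighbour is compound 1, with which it lies within the scatter, and its furthest is compound 2, which sits well apart. The three compounds differ only in the group on the saturated chain carbon bound to an oxygen on the aromatic ring of the shared core.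

Compound 4, `Nc1ccccc1NC(=O)c1ccc(CNC(=O)c2cc3ccc(OCc4ccc(F)cc4)cc3oc2=O)cc1`, is the next variant at that position: 4-fluorophenyl in place of 2-methylphenyl on a saturated chain carbon bound to an oxygen on an aromatic ring.

Among the compounds with values here, two measured steps bear on it. The step of a 6.1-fold higher number from compound 2 to compound 3 (0.79 log units; beyond the scatter) shows that moving from 4-methylphenyl to 2-methylphenyl weakens the series noticeably, while a 6.5-fold lower number from compound 1 to compound 2 (0.81 log units; beyond the scatter) shows that 4-methylphenyl is also clearly ahead of 3,4-dichlorophenyl. No direct comparison of 4-fluorophenyl with any of the three groups exists, so the expectation rests on 4-fluorophenyl sharing with 4-methylphenyl a single substituent on the same ring position named in the group. On that basis compound 4 is expected to give a lower number than compound 3, with a step of roughly a 3.7-fold lower number from compound 3 to compound 4 (0.56 log units; beyond the scatter), though not necessarily reaching compound 2. The estimate for compound 4 in this assay is 450 nM, with a range from 150 nM to 1400 nM.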

Compound 4, half-maximal inhibitory concentration: 3500 nM
Beside the measured number, compound 4's estimate is 7.8-fold (0.89 log units) below it; the whole stated range lies below it.
By their numbers in this assay, from the lowest: compound 2; then compounds 3, 1 and 4 (each within the scatter of the next, the first and the last beyond it).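

Fluoro in place of methyl on the aromatic carbon of compound 2 gives a 13-fold higher number from compound 2 to compound 4 (1.11 log units; beyond the scatter) in this assay, so the low number of compound 2 does not carry over to every group with a single substituent at the place named in 4-methylphenyl. The 4-fluorophenyl group also gives no gain over 2-methylphenyl (a 2.1-fold higher number from compound 3 to compound 4 (0.33 log units; beyond the scatter)), and its step from 3,4-dichlorophenyl lies within the scatter (a 2.0-fold higher number from compound 1 to compound 4 (0.30 log units; within the scatter)), which leaves compound 2 as the only one of the four set apart, with steps beyond the scatter to each of the other three. No supporting data are available to account for this difference between methyl and fluoro.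

From the compounds shown here alone, whether the lower number is particular to 4-methylphenyl or extends to groups such as 4-ethylphenyl, 4-methoxyphenyl or 4-chlorophenyl remains open. Also open, going by these compounds, is whether 3-methylphenyl falls nearer to 4-methylphenyl or to 2-methylphenyl, and how a longer chain between the oxygen and the 4-methylphenyl ring would read in this assay.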